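Cytotoxicity limits in the benzyl series: changing the dichlorobenzyl group

This account rests on a few compounds, and the source may have more. Where it says the series, first, only, none or still open, it means among the compounds named here.

Measured in a functional assay on MT4 cells (Homo sapiens) for cytotoxicity, read by MTT assay; a lower number here means that less compound is tolerated, a higher number that more compound is tolerated:
- compound 1 `Cc1c(O)nc(SCc2ccc([N+](=O)[O-])cc2)nc1Cc1c(Cl)cccc1Cl`: > 58000 nM (a limit)
- compound 2 `Cc1c(O)nc(SCc2cccc(C#N)c2)nc1Cc1c(Cl)cccc1Cl`: > 60000 nM (a limit)

Neither value is a number. Compound 1 stands only at its limit of > 58000 nM.

The next structure is compound 3 `Cc1c(O)nc(SCc2ccc([N+](=O)[O-])cc2)nc1Cc1ccc(F)cc1`, which is not yet measured. The change from compound 1 is 4-fluorophenyl in place of 2,6-dichlorophenyl on a saturated chain carbon bound to an aromatic carbon, or 2,6-dichlorobenzyl to 4-fluorobenzyl when cut one bond further out.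

Among the measured compounds shown here, only one measured step is available, a step that the two limits leave unreadable from compound 1 to compound 2. It gives no size to carry over, and it concerns a different place: 3-cyanophenyl in place of 4-nitrophenyl on a saturated chain carbon bound to a sulfur. For the measured compounds named here, no measured step touches the 2,6-dichlorophenyl group. No step beyond the scatter is therefore expected in this assay, and no direction can be assigned. The expected step is a step that the limit leaves unreadable from compound 1 to compound 3. For compound 3 the estimate is 65000 nM, with an expected range from 25000 nM to 130000 nM.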

Compound 3, half-maximal cytotoxic concentration: > 65000 nM
Compound 3: a limit, no number (the forecaster's own chance of this, stated with the estimate: 70%); the middle value lies on the limit itself.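

In this assay compound 3 gives > 65000 nM, a limit and not a number. Among the compounds shown here, compound 1 is also only a limit, so no step between compound 1 and compound 3 can be read. The compounds shown leave open whether 4-fluorophenyl in place of 2,6-dichlorophenyl shifts the concentration tolerated in this assay, and in which direction.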